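Amide-nitrogen substituent changes in the shared-core series

The source may report more compounds than this note shows. Statements on the series, on what has been measured and on what is new or still open speak of the compounds shown alone.

For the measured compounds named here, compound 2 `COc1ccc2c(=O)c(/C=C/C(=O)Nc3ccc(F)cc3)coc2c1` gives 26800 nM in a functional assay on A549 cells (Homo sapiens) for inhibition, read by MTT assay, with a stated time of 48 h (a lower number here means a stronger inhibitor, a higher number a weaker inhibitor), and is the only plain number in the set. Compound 1 `COc1ccc2c(=O)c(/C=C/C(=O)Nc3cccc(C)c3)coc2c1` sits at a limit, > 100000 nM in this assay. Going by the values given here, the single measured step, an at least 3.7-fold lower number from compound 1 to compound 2 (0.57 log units; beyond the scatter), has its size bounded by the limit of > 100000 nM in this assay, at which 1 of the 2 values shown sits. Compound 3 `COc1ccc2c(=O)c(/C=C/C(=O)NCc3ccc(F)cc3F)coc2c1` differs from compound 2 by 2,4-difluorobenzyl in place of 4-fluorophenyl on an amide-type nitrogen. Among the compounds with values here, the change sits at the same position as the measured step, but no measured step tests a benzyl against a phenyl, so no shift beyond the scatter is expected. The estimated step is a 1.1-fold higher number from compound 2 to compound 3 (0.05 log units; within the scatter). Compound 3 is expected near 30000 nM, within 8000 nM to 100000 nM.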

Compound 3, half-maximal inhibitory concentration: 13300 nM
Beside the measured number, compound 3's estimate is 2.3-fold (0.35 log units) above it, within the range that was stated.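

In this assay, a benzyl group on the amide-type nitrogen now stands against a phenyl group: 2,4-difluorobenzyl in place of 4-fluorophenyl gives a 2.0-fold lower number from compound 2 to compound 3 (0.30 log units; within the scatter). This position therefore accepts the larger group with no shift beyond the scatter, while 2,4-difluorobenzyl in place of 3-methylphenyl gives an at least 7.5-fold lower number from compound 1 to compound 3 (0.87 log units; beyond the scatter). Compound 1 is a limit, not a number, and this bounds the size of that step: the limit of > 100000 nM in this assay, at which 1 of the 3 values shown sits.

The effects of the added benzyl carbon and the second fluorine remain unseparated. Also open, as far as these compounds go, is how an amine, a carboxylic acid or a longer chain on this nitrogen would read.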